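Cytotoxicity in a pyrrolidinone series: the pyridin-2-yl step

This account rests on a few compounds, and the source may have more. Where it says the series, first, only, none or still open, it means among the compounds named here.

Measured compounds:
Compound 1, `COc1ccc([C@H]2CC(=O)N(Cc3cccc(C#N)c3)C2)cc1OC1CCCC1` — in a functional assay on HEK293 cells (Homo sapiens) for cytotoxicity (on this read-out higher numbers stand for lower toxicity in this test and lower numbers for higher toxicity in this test), compound 1 gives > 10000 nM, a limit of the assay.
Compound 2, `COc1ccc([C@H]2CC(=O)N(Cc3cccc(N)c3)C2)cc1OC1CCCC1` — compound 2 gives > 10000 nM, likewise a limit.
Compound 3, `COc1ccc([C@H]2CC(=O)N(c3ccccc3)C2)cc1OC1CCCC1` — compound 3 gives > 10000 nM, again a limit.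

Compound 2 stands at the limit of this assay, where every value shown so far also sits: the limit of > 10000 nM in this assay, at which 3 of the 3 values shown sit. The measured steps around it are therefore unreadable: a step that the two limits leave unreadable from compound 1 to compound 2, a step that the two limits leave unreadable from compound 1 to compound 3 and a step that the two limits leave unreadable from compound 2 to compound 3.

Compound 4, `COc1ccc([C@H]2CC(=O)N(c3ccccn3)C2)cc1OC1CCCC1`, differs from compound 2 as follows: pyridin-2-yl in place of 3-aminobenzyl on an amide-type nitrogen in a ring. Among the measured compounds shown here, the steps that bear on it are those that exchange the group on the amide-type nitrogen in the ring, a step that the two limits leave unreadable from compound 2 to compound 3 and a step that the two limits leave unreadable from compound 1 to compound 3; neither gives a size, so no direction is readable and nothing beyond the scatter is indicated. The expectation for compound 4 is therefore a value at or past the limit, with the step that the limit leaves unreadable from compound 2 to compound 4 expected to be none beyond the scatter. The estimate for compound 4 is 15000 nM, ranging from 7000 nM to 40000 nM.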

Compound 4, half-maximal cytotoxic concentration: > 10000 nM
Compound 4 was reported as a limit; the forecaster's own chance of this, stated with the estimate: 85%; the middle value does not contradict the limit.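

In this assay compound 4 gives > 10000 nM as a limit. No new step can be read among compound 1, compound 2, compound 3 and compound 4, with all of them at one limit: the limit of > 10000 nM in this assay, at which 4 of the 4 values shown sit.

Going by these compounds, whether any group on the amide-type nitrogen in the ring gives a value short of this limit in this assay stays open.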